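A phenyl group replaces hydrogen in compound 4

This account rests on a few compounds, and the source may have more. Where it says the series, first, only, none or still open, it means among the compounds named here.

- compound 1 `CCN1CCc2c(sc(NC=O)c2C(N)=O)C1` at > 25000 nM (a limit)
- compound 2 `CC(C)(C)OC(=O)CCCCC[N+]1(C)CCc2c(sc(NC(=O)Nc3ccc(Cl)cc3)c2C(N)=O)C1` at 110 nM
- compound 3 `CCN1CCc2c(sc(NC(=O)Nc3ccc(Cl)cc3)c2C(=O)c2nc(C)no2)C1` at > 25000 nM (a limit)

Compound 1 gives > 25000 nM in a functional assay (strain AB) with Danio rerio as the target, read by microscopy, with a stated time of 1 h (on this read-out lower numbers stand for an effect already at smaller amounts and higher numbers for an effect only at larger amounts of compound), as a limit and not as a number. Compound 3 gives > 25000 nM as a limit too. Compound 1 therefore stands at the limit of > 25000 nM in this assay, at which 2 of the 3 values shown sit, in these data. For the measured compounds named here, compound 2 gives 110 nM as the only number. Compound 4 `CCN1CCc2c(sc(NC(=O)c3ccccc3)c2C(N)=O)C1` carries phenyl in place of hydrogen on a carbonyl carbon and has not yet been measured. In this assay a small move to lower numbers is expected, with the estimated at least 1.2-fold lower number from compound 1 to compound 4 (0.09 log units; that floor lies within the scatter) staying modest, and the result may well remain at the limit. For compound 4 the expected value is 20000 nM with an estimated range from 5000 nM to 50000 nM in this test.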

Compound 4, half-maximal effective concentration: > 25000 nM
Compound 4 ended at the assay's limit; the forecaster's own chance of this, stated with the estimate: 60%; middle value at least 1.2-fold (0.09 log units) from the limit.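

Compound 1 and compound 4 both end at a limit and not at a number, so no step can be read between them. The compounds shown leave open whether phenyl in place of hydrogen on a carbonyl carbon changes the value at all.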